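Swapping an Amide Cap from Fluorocyclobutyl to Methylthiazolyl

The source may report more compounds than this note shows. Statements on the series, on what has been measured and on what is new or still open speak of the compounds shown alone.

Of the compounds shown here, three have so far been tested in an assay on HEK293 cells for negative allosteric modulation of metabotropic glutamate receptor 5 (Homo sapiens), read by FLIPR, with a stated time of 1 h; on this read-out lower numbers stand for stronger inhibition and higher numbers for weaker inhibition. Compound 1 `O=C1NCCc2nc(C#Cc3cccc(F)c3)sc21` gives > 10000 nM, which is a limit of the assay rather than a measured number. Compound 2 `O=C1NCCc2nc(C#Cc3ccccc3F)sc21` likewise reaches only the limit > 10000 nM. Compound 3 `O=C(C1CC(F)C1)N1CCc2nc(C#Cc3ccccc3)sc2C1`, the starting point of the step followed here, also sits at the limit > 10000 nM. On the numbers shown, compound 3 therefore stands nowhere in particular: every value is a limit, as the limit of > 10000 nM in this assay, at which 3 of the 3 values shown sit, records, and none of the three compounds can be ranked against another.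

Compound 4 `Cc1nc(C(=O)N2CCc3nc(C#Cc4ccccc4)sc3C2)cs1` differs from compound 3 in a single place:

2-methyl-1,3-thiazol-4-yl in place of 3-fluorocyclobutyl on a carbonyl carbon

Within the data shown here, no step between two measured compounds is available, so the effect of this change cannot be read from a precedent; the shared core has so far given nothing below the limit in this assay. Because all three values shown sit at the limit of > 10000 nM in this assay, at which 3 of the 3 values shown sit, the outlook for a new amide cap is cautious. The step expected here, a number no higher from compound 3 to compound 4 (the limit leaves the size open), is none beyond the usual scatter. Compound 4 is accordingly estimated at 10000 nM, with a range from 2500 nM to 40000 nM, and most probably will again be reported only as a limit.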

Compound 4, half-maximal inhibitory concentration: > 10000 nM
Compound 4: no number, only a limit; the forecaster's own chance of this, stated with the estimate: 70%; the middle value sits exactly at the limit.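

Among these compounds, compound 3 and compound 4 both stop at a limit of the assay rather than a number, so replacing 3-fluorocyclobutyl with 2-methyl-1,3-thiazol-4-yl gives no step that can be read: the limit of > 10000 nM in this assay, at which 4 of the 4 values shown sit.

The compounds shown leave open whether any amide cap on the shared core can give a true number in this assay at all.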